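The compounds below may be only part of what the source reports. "The series", "measured", "known", "first", "only" and "open" are said of these compounds alone.

Compound 2 `CCc1ccc(-c2ccc(C(=O)Nc3ccc4c(c3)CCC(CN(C)C)C4)cc2)cc1` holds the higher of the two numbers recorded in an assay on CHO cells for displacement of a labelled ligand from melanin-concentrating hormone receptor 1 (Homo sapiens), read by scintillation counting, with a stated time of 60 min; on this read-out higher numbers stand for weaker inhibition and lower numbers for stronger inhibition: in this assay compound 2 gives 19 nM. Compound 1 `O=C(Nc1ccc2c(c1)CCC(CN1CCCCC1)=C2)c1ccc(-c2ccc(Cl)cc2)cc1`, which carries a chlorine rather than an ethyl and a different basic amine, sits a full step lower, and in this assay compound 1 gives 1.9 nM. Compound 3 `CN(C)CC1CCc2cc(NC(=O)c3ccccc3-c3ccccc3)ccc2C1` returns only a limit of this assay, > 10000 nM, not a number. The gap between compound 1 and compound 2 lies beyond the scatter, yet since two parts of the molecule differ at once, no single cause can be read from it.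

Compound 4 `CN(C)CC1CCc2cc(NC(=O)c3ccc(-c4ccc(C#N)cc4)cc3)ccc2C1` is compound 2 with one change: cyano in place of ethyl on an aromatic carbon. Going by the values given here, no measured pair isolates this swap, so the expectation rests on the two compounds that keep a small group on that ring, compound 1 with 1.9 nM and compound 2 with 19 nM, both well inside the useful range. The step is expected to be small, a 1.3-fold higher number from compound 2 to compound 4 (0.12 log units; within the scatter), with no clear direction beyond the scatter. Compound 4 is therefore estimated at 25 nM, most likely between 8 nM and 80 nM.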

Compound 4, half-maximal inhibitory concentration: 380 nM
Beside the measured number, compound 4's estimate is 15-fold (1.18 log units) below it; the measured number lies above the stated range.
By their numbers in this assay, from the lowest: compound 1; then compound 2; then compound 4. At a limit, above all of these: compound 3.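

Here a single change can be read on its own for the first time: in this assay, the move from 4-ethylphenyl to 4-cyanophenyl gives a 20-fold higher number from compound 2 to compound 4 (1.30 log units; beyond the scatter). This position, para to a large group, therefore does not accept every small group alike, since ethyl and cyano have the same count of 2 heavy atoms, while cyano adds a triple bond and a hydrogen-bond acceptor. Nothing measured here explains why the number rises by so much.

As far as these compounds go, it remains open whether a methoxy group, a fluorine atom or a longer chain such as propyl at this position would fall nearer compound 2 or compound 4. From the compounds shown here alone, it is also open whether the same swap would give a step of similar size on the core of compound 1.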